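The source may hold more compounds than are shown below. What is called first, only, known or untested is meant among the compounds shown, and "the series" means these compounds.

Two compounds have been measured in a functional assay on MDA-MB-231 cells (Homo sapiens) for cytotoxicity, read by MTT assay, with a stated time of 48 h; on this read-out higher numbers stand for weaker inhibition and lower numbers for stronger inhibition:

Compound 1 `O=C(/C=C/c1ccc2c(c1)B(O)OC2)c1ccc(Br)cc1`: 9500 nM
Compound 2 `CSc1ccc(C(=O)/C=C/c2ccc3c(c2)B(O)OC3)cc1`: 9800 nM

Compound 2 and compound 1 share one core and differ only in the group on the far aromatic ring. Their two numbers lie within the usual scatter of each other, so neither can be called the more or less potent; the step of a 1.0-fold higher number from compound 1 to compound 2 (0.01 log units; within the scatter) says the same. Going by the values given here, compound 2 therefore stands level with the only other measured compound.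

Compound 3 `O=C(/C=C/c1ccc2c(c1)B(O)OC2)c1ccc(C(F)(F)F)cc1` is the next member of the series. It differs from compound 2 in one place: trifluoromethyl in place of methylsulfanyl on an aromatic carbon. Among the compounds with values here, only one measured step bears on this, the exchange of the same position that leads from compound 1 to compound 2, and that step, a 1.0-fold higher number from compound 1 to compound 2 (0.01 log units; within the scatter), stayed within the scatter. Replacing the group at this position once more is therefore expected to give no step beyond the scatter in this assay, in either direction, so no change at the digits printed from compound 2 to compound 3 (within the scatter) is the estimated step from compound 2 to compound 3. Compound 3 is accordingly expected to give about 9800 nM, with a likely range from 4000 nM to 24000 nM.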

Compound 3, half-maximal inhibitory concentration: 9200 nM
Compound 3: middle estimate off by 1.1-fold (0.03 log units), on the high side; low and high end bracket the measured number.
By their numbers in this assay, from the lowest: compounds 3, 1 and 2 (each within the scatter of the next).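

In this assay, putting trifluoromethyl in place of methylsulfanyl gives a 1.1-fold lower number from compound 2 to compound 3 (0.03 log units; within the scatter), and putting it in place of bromo gives a 1.0-fold lower number from compound 1 to compound 3 (0.01 log units; within the scatter). Going by these compounds alone, this position has now carried three different groups with all three numbers level, and that holds even though trifluoromethyl has more heavy atoms than methylsulfanyl and lacks its hydrogen-bond acceptor, so the single flat step seen earlier now extends to a second and third exchange. There is no measured information on why these groups stand level in this assay.

What the compounds leave open is whether any group at this position can move the number beyond the scatter, since an amine, a carboxylic acid or a longer chain there could either stay level with these three or depart from them. Also open, on these data alone, is whether the level seen here would hold if the shared core were altered, since all three compounds carry the same core and differ only in this one group.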